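The compounds below may be only part of what the source reports. "The series", "measured", "known", "first", "only" and "open" are said of these compounds alone.

For the measured compounds named here, in an ADME assay for pharmacokinetics (a higher number here means that the compound lasts longer, a lower number that the compound disappears faster), compound 1 `CC[C@H](c1ccc(O)cc1)[C@@H](CC)c1ccc(OCC(O)CCl)cc1` gives 0.5 h and compound 2 `CC[C@H](c1ccc(O)cc1)[C@@H](CC)c1ccc(OCC2CO2)cc1` gives 4 h as the higher of the two numbers so far, clear of the scatter of repeat measurements. Compound 3 `CC[C@H](c1ccc(O)cc1)[C@@H](CC)c1ccc(C(=O)CBr)cc1` keeps the shared core but swaps a whole group on it, and (bromomethyl)carbonyl in place of (oxiran-2-yl)methoxy on an aromatic carbon sums up that change: (bromomethyl)carbonyl in place of (oxiran-2-yl)methoxy on an aromatic carbon. Going by the values given here, only one measured step bears on this swap, namely an 8.0-fold higher number from compound 1 to compound 2 (0.90 log units; beyond the scatter) as a modest move beyond the scatter, and it too took place within this group. It gives no direct reading for a bromine-bearing carbonyl, so the forecast is loose. Among the compounds with values here, the only halogen-bearing group measured so far belongs to compound 1 with 0.5 h at the low end, which points to a fall rather than a rise in this assay from the number of compound 2. A downward move is therefore expected, and a 4.0-fold lower number from compound 2 to compound 3 (0.60 log units; beyond the scatter) is the estimated step. For compound 3 the estimated half-life is 1 h within a range of 0.25 h to 3 h for repeat measurements.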

Compound 3, half-life: < 0.5 h
Compound 3: a limit, no number (the forecaster's own chance of this, stated with the estimate: 10%); middle value at least 2.0-fold (0.30 log units) from the limit.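

In this assay compound 3 gives < 0.5 h, which is a limit of the assay and not a number. The earlier step changed only the end of the chain on the ring oxygen, whereas putting (bromomethyl)carbonyl in place of (oxiran-2-yl)methoxy on this aromatic carbon, para to a large group, replaces the whole group and gives an at least 8.0-fold lower number from compound 2 to compound 3 (0.90 log units; beyond the scatter), so the longer half-life of compound 2 does not survive this swap. Of the three compounds, only compound 2 carries the three-membered ring, and it stands clear of both others, but the data give only a number no higher from compound 1 to compound 3 (the limit leaves the size open) and that step cannot be read for size: the limit of < 0.5 h in this assay, at which 1 of the 3 values shown sits.

The compounds shown leave open whether the fall goes with the loss of the three-membered ring, the arrival of the bromine, the carbonyl, or the missing ring oxygen, as all of these change together in this one step. Also open, as far as these compounds go, is how a methyl ketone, which is the carbonyl without its bromine, an amine or a carboxylic acid would behave on this aromatic carbon.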